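A few compounds are considered here, and "the series" means these few. Any claim that something is new, unique, unknown or untested is made for them only; others in the source may bear on it.

Three compounds that share one core have results in a functional assay on Caco-2 cells (Homo sapiens) for antiproliferative activity, with a stated time of 48 h; on this read-out lower numbers stand for stronger inhibition and higher numbers for weaker inhibition. Compound 1 `CCN(CC)c1ccc(-c2ccc(C#N)cc2)nn1`, with a cyano group, gives > 25000 nM, which is a limit of the assay and not a number. Compound 2 `CCN(CC)c1ccc(-c2ccc(C(C)=O)cc2)nn1`, with an acetyl group in that place, gives 15000 nM. Compound 3 `CCN(CC)c1ccc(-c2ccc(C(=O)OC)cc2)nn1`, with a methoxycarbonyl group, gives 250 nM, the lower of the two true numbers and the best result of the three.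

Compound 4 `CCN(CC)c1ccc(-c2ccc(C(=O)O)cc2)nn1` differs from compound 3 in one place, with hydrogen in place of methyl on an oxygen next to a carbonyl group, turning methoxycarbonyl to carboxy: hydrogen in place of methyl on an oxygen next to a carbonyl group. This exact change has not been measured, so the nearest evidence comes from the other steps. The step of a 60-fold lower number from compound 2 to compound 3 (1.78 log units; beyond the scatter) is large and changes what sits on the same carbonyl carbon. The step of an at least 100-fold lower number from compound 1 to compound 3 (2.00 log units; beyond the scatter) is also large. The step of an at least 1.6-fold lower number from compound 1 to compound 2 (0.22 log units; that floor lies within the scatter) adds little. For the measured compounds named here, compound 3 is so far the only compound with a low number, as its step of a 60-fold lower number from compound 2 to compound 3 (1.78 log units; beyond the scatter) shows, so losing the methoxy group is expected to raise the number in this assay, probably well beyond the scatter. The expected change is a 24-fold higher number from compound 3 to compound 4 (1.38 log units; beyond the scatter). The estimate for compound 4 is 6000 nM, with an expected range from 800 nM to 25000 nM.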

Compound 4, half-maximal inhibitory concentration: > 25000 nM
Compound 4: no number, only a limit; the forecaster's own chance of this, stated with the estimate: 25%; middle value at least 4.1-fold (0.61 log units) away from the limit.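

In this assay, the methyl on the oxygen next to a carbonyl group turns out to matter: putting hydrogen in its place gives an at least 100-fold higher number from compound 3 to compound 4 (2.00 log units; beyond the scatter), so the low number seen with methoxycarbonyl does not carry over to carboxy. Against the acetyl compound, the result is an at least 1.6-fold higher number from compound 2 to compound 4 (0.22 log units; that floor lies within the scatter); that floor lies within the scatter, so these data do not separate carboxy from acetyl, and among the four compounds only methoxycarbonyl gives a low number. The step between compound 1 and compound 4 cannot be read, because both compounds stand at the same limit, which is not a number: the limit of > 25000 nM in this assay, at which 2 of the 4 values shown sit.

The compounds shown leave open whether that oxygen needs a methyl in particular, which an ethyl or a longer chain in the same place would test, and whether an amide, with nitrogen in place of that oxygen, would keep the low number. They also leave open whether the gap between methoxycarbonyl and carboxy holds on the shared core outside this assay, for instance on other cell lines.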